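Ester to acid on the benzyl arm: cytotoxicity outlook

The compounds below may be only part of what the source reports. "The series", "measured", "known", "first", "only" and "open" are said of these compounds alone.

Compound 2 `COC(=O)c1ccc(CN2C(=O)/C(=C/c3cc(C)n(-c4ccc(O)c(C(=O)O)c4)c3C)SC2=S)cc1` and compound 1 `Cc1cc(/C=C2\SC(=S)N(Cc3ccc(C(F)(F)F)cc3)C2=O)c(C)n1-c1ccc(O)c(C(=O)O)c1` share a core and differ in a single group. Among the measured compounds shown here, in an ADME assay on MT2 cells (Homo sapiens) for cytotoxicity, read by XTT assay, with a stated time of 4 days (on this read-out lower numbers stand for higher toxicity in this test and higher numbers for lower toxicity in this test), compound 1 gives 45900 nM, and compound 2 gives 36900 nM; the step of a 1.2-fold lower number from compound 1 to compound 2 (0.09 log units; within the scatter) means the two numbers cannot be told apart, so compound 2 stands level with the only other compound measured. Compound 3 `Cc1cc(/C=C2\SC(=S)N(Cc3ccc(C(=O)O)cc3)C2=O)c(C)n1-c1ccc(O)c(C(=O)O)c1` differs from compound 2 by hydrogen in place of methyl on an oxygen next to a carbonyl group. For the measured compounds named here, the one measured step touches the same group and stayed within the scatter, so no shift beyond the scatter is expected in this assay; the expected step is a 1.1-fold higher number from compound 2 to compound 3 (0.04 log units; within the scatter). Compound 3 is estimated at 40000 nM, between 15000 nM and 100000 nM.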

Compound 3, half-maximal cytotoxic concentration: 105000 nM
Estimate against measurement, compound 3: 2.6-fold (0.42 log units) below; measured number above the stated range.
By their numbers in this assay, from the lowest: compounds 2 and 1 (each within the scatter of the next); then compound 3.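

In this assay, this position turns out to respond after all: carboxy in place of methoxycarbonyl raises the number (a 2.8-fold higher number from compound 2 to compound 3 (0.45 log units; beyond the scatter)), and carboxy in place of trifluoromethyl does too (a 2.3-fold higher number from compound 1 to compound 3 (0.36 log units; beyond the scatter)). Both steps are modest but beyond the scatter, which makes compound 3 the least toxic of the three in this test, while the two groups without the free hydrogen on oxygen could not be told apart. Nothing available here accounts for the shift. From the compounds shown here alone, it remains open whether the shift is particular to carboxy, or whether an amine or a primary amide at this position would move the number the same way.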